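Selenium-benzyl replacement of methylsulfanyl on two acylamidine cores

A few compounds are considered here, and "the series" means these few. Any claim that something is new, unique, unknown or untested is made for them only; others in the source may bear on it.

The measured compounds are compound 1 `CS/C(=N\C(=O)c1csc([N+](=O)[O-])c1)NC(=O)c1csc([N+](=O)[O-])c1` with 21400 nM, compound 2 `O=C(/N=C(/NC(=O)c1csc([N+](=O)[O-])c1)[Se]Cc1ccccc1)c1csc([N+](=O)[O-])c1` with 54100 nM and compound 3 `CS/C(=N\C(=O)c1cnc2ccccc2c1)NC(=O)c1cnc2ccccc2c1` with 42200 nM, all in an ADME assay on MCF-10A cells (Homo sapiens) for cytotoxicity, read by MTT assay, with a stated time of 72 h; on this read-out higher numbers stand for weaker inhibition of growth and lower numbers for stronger inhibition of growth.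

Compound 1 and compound 2 share one core and differ by a group of 8 heavy atoms (7 carbon, 1 selenium; one six-membered aromatic ring of carbon only) in place of a group of 2 heavy atoms (1 carbon, 1 sulfur; no ring), on a carbon with a double bond to nitrogen. The step this change made is a 2.5-fold higher number from compound 1 to compound 2 (0.40 log units; beyond the scatter). Compound 3 carries a different core; the difference between the two cores is not broken down here. Compound 3 stands second highest of the three numbers, within the scatter of compound 2 and within the scatter of compound 1, so no order among compound 3 and its neighbours can be claimed.

Compound 4 `O=C(/N=C(/NC(=O)c1cnc2ccccc2c1)[Se]Cc1ccccc1)c1cnc2ccccc2c1` is not yet measured. It differs from compound 3 by a group of 8 heavy atoms (7 carbon, 1 selenium; one six-membered aromatic ring of carbon only) in place of a group of 2 heavy atoms (1 carbon, 1 sulfur; no ring), on a carbon with a double bond to nitrogen, which is the same change as that from compound 1 to compound 2, and it occurs twice among the compounds shown. Within the data shown here, the expectation for compound 4 rests on this one earlier step, because a 2.5-fold higher number from compound 1 to compound 2 (0.40 log units; beyond the scatter) is the only measured instance of the change. Compound 4 is therefore expected to show a step of about a 2.3-fold higher number from compound 3 to compound 4 (0.35 log units; beyond the scatter) from compound 3. With the starting value of compound 3 at 42200 nM, compound 4 is estimated at 95000 nM, likely lying between 40000 nM and 220000 nM.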

Compound 4, concentration for total growth inhibition: > 100000 nM
Compound 4 gave a limit, no number; the forecaster's own chance of this, stated with the estimate: 25%; at least 1.0-fold (0.02 log units) between middle value and limit.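

In this assay compound 4 gave > 100000 nM, which is a limit of the assay and not a number. Even so, the step can be read as an at least 2.3-fold higher number from compound 3 to compound 4 (0.37 log units; beyond the scatter), so replacing methylsulfanyl with the selenium-benzyl group on a carbon with a double bond to nitrogen raised the number on the second core as it did on the first, meaning weaker inhibition of growth on both. This shows that the direction of the change carried over between these two cores, but it does not show that the size carried over, and the two steps can only be set side by side as follows: the same change on two cores in this assay, a 2.5-fold higher number (0.40 log units; beyond the scatter) from compound 1 to compound 2 and an at least 2.3-fold higher number (0.37 log units; beyond the scatter) from compound 3 to compound 4; the limit leaves it open whether they differ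

The change swaps the sulfur for selenium and the methyl for benzyl in a single move, and the compounds shown include neither a benzylsulfanyl nor a methylselanyl group on that carbon, leaving open how much of the step belongs to each part. Also open, going by these compounds, is whether the same direction would hold on further cores or for other groups at that carbon, such as an amine or a longer alkyl chain on the sulfur.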